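The source may hold more compounds than are shown below. What is called first, only, known or untested is meant among the compounds shown, and "the series" means these compounds.

Among the measured compounds shown here, compound 2 `CC(C)(C)CCc1cnc(CCc2ccc(-c3ccccc3C(=O)O)cc2)[nH]1` gives the lowest of the two numbers measured so far in an in vitro functional assay on cells for agonist activity at Bombesin receptor subtype-3 (Mus musculus), read by luminescence and calcium flux (on this read-out higher numbers stand for an effect only at larger amounts of compound and lower numbers for an effect already at smaller amounts), with compound 2 at 6.2 nM. Compound 1 `O=C(O)c1ccccc1-c1ccc(CCc2ncc(Cc3ccc(Cl)cc3)[nH]2)cc1` reaches 102 nM in this assay, and the one difference between the two lies in the group on a saturated chain carbon bound to an aromatic carbon: a 16-fold lower number from compound 1 to compound 2 (1.22 log units; beyond the scatter).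

Compound 3 `O=C(O)c1ccccc1-c1ccc(CCc2ncc(Cc3cccc(F)c3F)[nH]2)cc1` differs from compound 2 in the same position: 2,3-difluorophenyl in place of neopentyl on a saturated chain carbon bound to an aromatic carbon. For the measured compounds named here, this returns an aromatic group to the place where compound 1 also carries one, so the step from compound 1 to compound 2 is the only measured step that bears on it, and it ran in the opposite direction with a large size. The expectation for compound 3 is therefore a number well above that of compound 2 and near that of compound 1, so that a 13-fold higher number from compound 2 to compound 3 (1.11 log units; beyond the scatter) is expected. For compound 3 the estimated value in this assay is 80 nM, with a range from 25 nM to 300 nM.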

Compound 3, half-maximal effective concentration: 8 nM
Estimate against measurement, compound 3: 10-fold (1.00 log units) above; the measured number lies below the stated range.
By their numbers in this assay, from the lowest: compounds 2 and 3 (each within the scatter of the next); then compound 1.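

Carrying an aromatic ring on this saturated chain carbon does not by itself give a number as high as that of compound 1 in this assay: with 2,3-difluorophenyl in place of neopentyl there is a 1.3-fold higher number from compound 2 to compound 3 (0.11 log units; within the scatter), so the two groups cannot be told apart here, although one has a ring and the other has none. The choice of aromatic group does matter, since replacing 4-chlorophenyl with 2,3-difluorophenyl gives a 13-fold lower number from compound 1 to compound 3 (1.11 log units; beyond the scatter). No measurement available here explains this result.

4-Chlorophenyl and 2,3-difluorophenyl differ in the kind, number and placement of their halogen atoms all at once, so which of these accounts for the step stays open; plain phenyl or 4-fluorophenyl would help separate them. Going by these compounds, how a chain bearing an amine or a carboxylic acid would behave at this position also remains open.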